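This account rests on a few compounds, and the source may have more. Where it says the series, first, only, none or still open, it means among the compounds named here.

Compound 1 `CC(=O)c1ccc(NC(=O)C(CC(C)C)N(C(=O)c2ccccc2)S(=O)(=O)c2ccc([N+](=O)[O-])cc2)cc1` gives in a functional assay for inhibition, read by spectrophotometry, with a stated time of 20 min, tested at 5 mg/mL (on this read-out higher numbers stand for a stronger effect at the one concentration tested and lower numbers for a weaker effect), a value of 81.3%, the higher of the two numbers in hand. Compound 2 `CC(=O)c1ccc(NC(=O)C(C(C)C)N(C(=O)c2ccccc2)S(=O)(=O)c2ccc([N+](=O)[O-])cc2)cc1` gives 27.4%, and the step of a number 53.9 percentage points lower from compound 1 to compound 2 (beyond the scatter) was large. Compound 3 `CC(=O)c1ccc(NC(=O)C(CC(C)C)N(C(=O)c2ccccc2)S(=O)(=O)c2ccccc2)cc1` differs from compound 1 by hydrogen in place of nitro on an aromatic carbon. Within the data shown here, no measured step touches the (4-nitrophenyl)sulfonyl group; the only step in hand altered the saturated chain carbon, so it offers no guide here. The step of a number 16.3 percentage points lower from compound 1 to compound 3 (beyond the scatter) is expected to be modest and of uncertain direction. The estimate for compound 3 is 65%, within 35% to 90%.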

Compound 3, a percentage reported as inhibition, at one concentration (the size of the read-out at that concentration, not a potency): 52.2%
The estimate for compound 3 lay 12.8 percentage points above the measured number, and the stated range covers the measured number.
By their numbers in this assay, from the lowest: compound 2; then compound 3; then compound 1.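

In this assay hydrogen in place of nitro gives a number 29.1 percentage points lower from compound 1 to compound 3 (beyond the scatter) and so shows that this position on the aromatic ring, para to a large group, is sensitive to what it carries. Compound 3 still gives 52.2% at the one concentration tested, so the read-out does not vanish without the nitro group. Nothing at hand gives a reason for this step.

As far as these compounds go, whether an amine, a methoxy group or a chlorine atom at this position would match nitro or hydrogen remains open. Also open, from the compounds shown here alone, is whether the change would have the same size with the isopropyl chain of compound 2.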